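Furan to Thiophene Swap on the Longer-Chain Amide

This account rests on a few compounds, and the source may have more. Where it says the series, first, only, none or still open, it means among the compounds named here.

Measured so far:
Compound 1, `CCCCCCCCCCCCNC(=O)[C@@H](NC(=O)c1ccco1)[C@@H](C)O`, gives 147000 nM in a functional assay on HepG2 cells (Homo sapiens) for cytotoxicity, read by MTT assay, with a stated time of 48 h; on this read-out lower numbers stand for stronger inhibition and higher numbers for weaker inhibition.
Compound 2, `CCCCCCCCCCCCNC(=O)[C@@H](NC(=O)c1cccs1)[C@@H](C)O`, gives 30100 nM in this assay.
Compound 3, `CCCCCCCCCCCCCCCCCCNC(=O)[C@@H](NC(=O)c1ccco1)[C@@H](C)O`, gives 42300 nM in this assay.

Compound 4, `CCCCCCCCCCCCCCCCCCNC(=O)[C@@H](NC(=O)c1cccs1)[C@@H](C)O`, is not yet measured. It differs from compound 3 by thiophen-2-yl in place of furan-2-yl on a carbonyl carbon. The same change is already measured once, on the core of compound 1: there it made a 4.9-fold lower number from compound 1 to compound 2 (0.69 log units; beyond the scatter). The place of the change reads the same in both pairs, so it is the same change. The two cores differ by hexyl in place of hydrogen on a saturated chain carbon, ten or more bonds along the chain from an amide-type nitrogen, a change that by itself made a 3.5-fold lower number from compound 1 to compound 3 (0.54 log units; beyond the scatter). Compound 2 and compound 3 give numbers within the scatter of each other.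

Going by the values given here, for compound 4 a step of about a 4.5-fold lower number from compound 3 to compound 4 (0.65 log units; beyond the scatter) in this assay is expected, resting on the single measured instance a 4.9-fold lower number from compound 1 to compound 2 (0.69 log units; beyond the scatter) on the other core, and with the caution that one pair is a thin basis. Compound 4 is therefore estimated at 9500 nM, expected to lie between 4000 nM and 25000 nM.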

Compound 4, half-maximal inhibitory concentration: 92000 nM
Estimate against measurement, compound 4: 9.7-fold (0.99 log units) below; measured number above the stated range.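

In this assay, thiophen-2-yl in place of furan-2-yl does not carry from one core to the other, with a 2.2-fold higher number from compound 3 to compound 4 (0.34 log units; beyond the scatter) on the longer-chain core, and the two instances run in opposite directions: the same change on two cores in this assay, a 4.9-fold lower number (0.69 log units; beyond the scatter) from compound 1 to compound 2 and a 2.2-fold higher number (0.34 log units; beyond the scatter) from compound 3 to compound 4, 11-fold (1.03 log units) apart, beyond the scatter of two such steps
Hexyl in place of hydrogen on the chain likewise reverses, giving a 3.1-fold higher number from compound 2 to compound 4 (0.49 log units; beyond the scatter) with thiophen-2-yl on the carbonyl, opposite to its step with furan-2-yl: the same change on two cores in this assay, a 3.5-fold lower number (0.54 log units; beyond the scatter) from compound 1 to compound 3 and a 3.1-fold higher number (0.49 log units; beyond the scatter) from compound 2 to compound 4, 11-fold (1.03 log units) apart, beyond the scatter of two such steps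
In these four compounds, the step for each change thus depends on the other place, but a single pair per core gives no rule for further cores and no cause for the reversal.

From the compounds shown here alone, it remains open whether a hexadecyl chain would follow the dodecyl or the octadecyl compounds. Going by these compounds, it is equally open how a phenyl group on the carbonyl would behave on either core.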